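The compounds below may be only part of what the source reports. "The series", "measured", "known", "first", "only" and "open" are said of these compounds alone.

Compound 1 `CCCCCCCCCCCCCCCC(=O)NCCC(=O)Nc1cccc(C(=O)Nc2cccc(C)c2C)c1` gives 11% in an in vitro assay on Sf9 cells for inhibition of CAAX prenyl protease 2 (Homo sapiens), tested at 10 uM; on this read-out higher numbers stand for more inhibition at the one concentration tested (going by the name of the read-out) and lower numbers for less inhibition.
Compound 2 `CCCCCCCCCCCCCCCC(=O)NCCC(=O)Nc1cccc(S(=O)(=O)Nc2cccc(C)c2C)c1` gives 18% in this assay.
Compound 3 `CCCCCCCCCCCCCCCC(=O)NCCC(=O)Nc1cccc(S(=O)(=O)NCc2cccc3ccccc23)c1` gives 20% in this assay.

Compound 2 stands second of these three numbers, but it is separated from neither neighbour by more than the usual scatter: the step of a number 7 percentage points higher from compound 1 to compound 2 (within the scatter) and the step of a number 2 percentage points higher from compound 2 to compound 3 (within the scatter) are both within it, so the three compounds cannot be ordered on this read-out.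

Compound 4 `CCCCCCCC/C=C\CCCCCCCC(=O)NCCC(=O)Nc1cccc(S(=O)(=O)Nc2cccc(C)c2C)c1` differs from compound 2 in the long acyl chain only: dec-1-en-1-yl in place of octyl on a saturated chain carbon, seven bonds along the chain from a carbonyl carbon. Within the data shown here, both measured steps concern the other end of the molecule, the aryl carbamoyl or sulfamoyl part, and neither of them touched the chain, so no measured step bears directly on this change. The two known steps were each small, and nothing in the data points to the chain as a place where the read-out moves. The step from compound 2 to compound 4 is therefore expected to stay within the scatter, no change at the digits printed from compound 2 to compound 4 (within the scatter). Compound 4 is estimated at 18% in this assay, with a range from 8% to 30%.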

Compound 4, a percentage reported as inhibition, at one concentration (the size of the read-out at that concentration, not a potency): < 5%
Compound 4: only a limit was reported; the forecaster's own chance of this, stated with the estimate: 0%; middle value at least 13 percentage points away from the limit.
By their numbers in this assay, from the lowest: compounds 1, 2 and 3 (each within the scatter of the next). At a limit, below all of these: compound 4.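

In this assay, the long acyl chain, which neither earlier step touched, proves to be a place where the read-out moves: dec-1-en-1-yl in place of octyl, on a saturated chain carbon seven bonds along the chain from a carbonyl carbon, gives a number at least 13 percentage points lower from compound 2 to compound 4 (beyond the scatter), the only step shown that lies beyond the scatter. Compound 4 stands at < 5%, which is a limit of the assay and not a number. The size of the step is therefore a bound, not a measured difference: the limit of < 5% in this assay, at which 1 of the 4 values shown sits.

The change brings a longer chain and a double bond together, so the compounds shown do not separate the two; a saturated decyl at the same place would bear on this. As far as these compounds go, it also remains open whether the same chain change would act alike on the carbamoyl compound 1 or the naphthalenylmethyl compound 3.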